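The source may hold more compounds than are shown below. What is called first, only, known or untested is meant among the compounds shown, and "the series" means these compounds.

Measured compounds in a functional assay on DLD-1 cells (Homo sapiens) for antiproliferative activity, read by trypan blue exclusion; a lower number here means a stronger inhibitor, a higher number a weaker inhibitor:

Compound 1 `COc1ccc(CS(=O)(=O)/C=C/c2cc(OC)c(OC)c(OC)c2)cc1`: > 20000 nM, a limit of the assay rather than a number.
Compound 2 `COc1ccc(CS(=O)(=O)/C=C/c2c(OC)cc(O)cc2OC)cc1`: > 20000 nM, likewise a limit of the assay.
Compound 3 `COc1ccc(CS(=O)(=O)/C=C/c2cc(OC)c(OC)c(OC)c2)cc1O`: 10000 nM.

Two of the three values sit at the limit of > 20000 nM in this assay, at which 2 of the 3 values shown sit, so only compound 3 gives a number in this assay. Compound 3 is made from compound 1 by a single change, (hydroxy in place of hydrogen on an aromatic carbon), and that change produced an at least 2.0-fold lower number from compound 1 to compound 3 (0.30 log units; that floor lies within the scatter). Because the starting value of compound 1 is the limit of > 20000 nM in this assay, at which 2 of the 3 values shown sit, the true size of that step is known only as a floor.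

Compound 2 differs from compound 1 in more than one place; the difference between the two cores is not broken down here. Compound 4 `COc1ccc(CS(=O)(=O)/C=C/c2c(OC)cc(O)cc2OC)cc1O` is not yet measured in this assay. Going by the values given here, it is made from compound 2 by hydroxy in place of hydrogen on an aromatic carbon, which is the same change as the one from compound 1 to compound 3, made around the same place.

For compound 4 a step of about an at least 1.3-fold lower number from compound 2 to compound 4 (0.12 log units; that floor lies within the scatter) is expected, resting on the floor of an at least 2.0-fold lower number from compound 1 to compound 3 (0.30 log units; that floor lies within the scatter) and on the limit of compound 2 at > 20000 nM. Compound 4 is therefore estimated at 15000 nM, expected to lie between 5000 nM and 40000 nM, with a real chance that this assay again reports only a limit.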

Compound 4, half-maximal inhibitory concentration: 500 nM
For compound 4 the middle estimate is 30-fold (1.48 log units) above the measured one, and the stated range ends above it.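

Carried to a second core, hydroxy in place of hydrogen on an aromatic carbon gave an at least 40-fold lower number from compound 2 to compound 4 (1.60 log units; beyond the scatter) in this assay, a large step. The number therefore falls in the same direction on both cores shown, although on the core of compound 1 the step is known only as a floor that lies within the scatter. This does not show that the size of the step carries over, and the two cores cannot be ranked by how much each gains from the change: the same change on two cores in this assay, an at least 2.0-fold lower number (0.30 log units; that floor lies within the scatter) from compound 1 to compound 3 and an at least 40-fold lower number (1.60 log units; beyond the scatter) from compound 2 to compound 4; the limit leaves it open whether they differ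

On these data alone, the true size of both steps stays open, as each of them starts from a limit rather than a number: the limit of > 20000 nM in this assay, at which 2 of the 4 values shown sit. Also open is whether an amine, a fluorine atom or a carboxylic acid on that same aromatic carbon would lower the number as hydroxy does in this assay, and whether the hydroxy already present on the core of compound 2 has any share in the large step.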